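The compounds below may be only part of what the source reports. "The series", "measured", "known", "first", "only" and "open" are said of these compounds alone.

Working notes on the series

Among the compounds with values here, compound 1 `COc1ccc(-c2cc(C(=O)/C=C/c3ccccc3)nc3cc(-c4ccccc4)nn23)cc1OC` gives 18600 nM in a functional assay on A549 cells (Homo sapiens) for antiproliferative activity, read by MTT assay, with a stated time of 24 h (a lower number here means a stronger inhibitor, a higher number a weaker inhibitor), the highest of the three numbers measured so far. Compound 3 `COc1cc(-c2cc(/C=C/C(=O)c3ccccc3)nc3cc(-c4ccccc4)nn23)cc(OC)c1OC` gives 18200 nM in this assay, and compound 2 `COc1ccc(-c2cc(/C=C/C(=O)c3ccc(C)c(C)c3)nc3cc(-c4ccccc4)nn23)cc1OC` gives 9300 nM; both lie within the usual scatter of the number for compound 1, so no order among the three can be read from this assay.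

Compound 4 `COc1ccc(C(=O)/C=C/c2cc(-c3ccc(OC)c(OC)c3)n3nc(-c4ccccc4)cc3n2)cc1` has not yet been measured. It differs from compound 1 in one place: 2-((4-methoxyphenyl)carbonyl)ethenyl in place of (2-phenylethenyl)carbonyl on an aromatic carbon. Within the data shown here, the only measured step that bears on this change is the one from compound 1 to compound 2, in which the same carbonyl-ethenyl linker is turned around and the distal phenyl ring carries substituents; that step gave a 2.0-fold lower number from compound 1 to compound 2 (0.30 log units; within the scatter). Among the measured compounds shown here, compound 3 differs from compound 1 elsewhere, and no step is given for that pair.

On that basis the change to compound 4 is expected to give at most a small step, with a 1.6-fold lower number from compound 1 to compound 4 (0.19 log units; within the scatter) expected, in the direction seen for compound 2. Compound 4 is therefore estimated at 12000 nM in this assay, within a range from 5000 nM to 28000 nM.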

Compound 4, half-maximal inhibitory concentration: 11900 nM
Beside the measured number, compound 4's estimate is 1.0-fold (0.00 log units) above it; the range from low to high includes it.
By their numbers in this assay, from the lowest: compounds 2, 4, 3 and 1 (each within the scatter of the next).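

In this assay, the turned-around carbonyl-ethenyl linker now appears with a second end group, 4-methoxyphenyl on the carbonyl carbon, and the step stays within the scatter (a 1.6-fold lower number from compound 1 to compound 4 (0.19 log units; within the scatter)). The series also gains its first comparison of end groups on that carbonyl carbon, 4-methoxyphenyl in place of 3,4-dimethylphenyl, which is likewise within the scatter (a 1.3-fold higher number from compound 2 to compound 4 (0.11 log units; within the scatter)). Neither of these two end groups on the reversed linker is therefore separated from compound 1 or from the other in this assay. No measurement of any kind bears on the reason for these small steps.

The effect of reversing the linker alone, with an unsubstituted phenyl end group, remains apart from the effect of the substituents. Also open, going by these compounds, is whether an amine or a carboxylic acid on that end ring would give a step beyond the scatter.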